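This account rests on a few compounds, and the source may have more. Where it says the series, first, only, none or still open, it means among the compounds named here.

Measured in an ADME assay on the whole organism for cytotoxicity, with Artemia salina as the target, with a stated time of 24 h; a higher number here means that more compound is needed for the effect, a lower number that less compound is needed:
compound 1 `CCc1cc(/C=C/C(=O)c2ccccc2NC(=O)NS(=O)(=O)c2ccc(C)cc2)cc(OC)c1OC` gives 19.2 ug/mL.
compound 2 `Cc1ccc(S(=O)(=O)NC(=O)Nc2ccccc2C(=O)/C=C/c2cc(O)ccc2[N+](=O)[O-])cc1` gives 18.3 ug/mL.
compound 3 `Cc1ccc(S(=O)(=O)NC(=O)Nc2ccccc2C(=O)/C=C/c2ccccc2Cl)cc1` gives 12.8 ug/mL.

Compound 3 has the lowest number of the three, but its gaps to both other compounds are within the scatter, so all three stand level in this assay. Compound 4 `Cc1ccc(S(=O)(=O)NC(=O)Nc2ccccc2C(=O)/C=C/c2ccc[nH]2)cc1` carries 1H-pyrrol-2-yl in place of 2-chlorophenyl on a double-bonded chain carbon bound to a double-bonded chain carbon. Going by the values given here, the steps that bear on this change are the earlier swaps of the group at the same place: a 1.5-fold lower number from compound 1 to compound 3 (0.18 log units; within the scatter), a 1.4-fold lower number from compound 2 to compound 3 (0.16 log units; within the scatter) and a 1.0-fold lower number from compound 1 to compound 2 (0.02 log units; within the scatter); none of them left the scatter. Three different groups at this place thus gave the same number, so for the 1H-pyrrol-2-yl group of compound 4 no step beyond the scatter is expected in this assay. Compound 4 is therefore estimated at 14 ug/mL, with a range of 7 ug/mL to 28 ug/mL, meaning an expected step of a 1.1-fold higher number from compound 3 to compound 4 (0.04 log units; within the scatter).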

Compound 4, concentration for half-maximal effect: 32.1 ug/mL
Compound 4: middle estimate off by 2.3-fold (0.36 log units), on the low side; measured number outside the range, above it.
By their numbers in this assay, from the lowest: compounds 3, 2, 1 and 4 (each within the scatter of the next, the first and the last beyond it).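

In this assay this place on a double-bonded chain carbon bound to a double-bonded chain carbon gives its first step beyond the scatter, a 2.5-fold higher number from compound 3 to compound 4 (0.40 log units; beyond the scatter), with 1H-pyrrol-2-yl in place of 2-chlorophenyl. Going by these compounds alone, the other two swaps to 1H-pyrrol-2-yl, a 1.8-fold higher number from compound 2 to compound 4 (0.24 log units; within the scatter) and a 1.7-fold higher number from compound 1 to compound 4 (0.22 log units; within the scatter), stay within the scatter, so the place is not fully silent, but only one pair separates. No available data explain this step. Open, going by these compounds, is whether 1-methyl-1H-pyrrol-2-yl or furan-2-yl at this place would stand with compound 4 or with compound 3.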